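A Third Aryl Group on a Shared Core

The source may hold more compounds than are shown below. What is called first, only, known or untested is meant among the compounds shown, and "the series" means these compounds.

Compound 1, `Cc1ccccc1CC[C@H](O)CC[C@@H]1[C@@H](CCCCCCC(=O)O)[C@@H](O)C[C@H]1O`: > 10000 nM
Compound 2, `COc1ccc(CC[C@H](O)CC[C@@H]2[C@@H](CCCCCCC(=O)O)[C@@H](O)C[C@H]2O)cc1`: > 10000 nM

In an in vitro assay on CHO-KI cells for displacement of a labelled ligand from thromboxane A2 receptor (Homo sapiens) (a lower number here means a stronger inhibitor, a higher number a weaker inhibitor), compound 1 gives > 10000 nM, which is a limit of the assay and not a number. Compound 2 gives > 10000 nM in this assay, again only a limit. The step between them, a step that the two limits leave unreadable from compound 1 to compound 2, therefore cannot be read, and both values sit at the limit of > 10000 nM in this assay, at which 2 of the 2 values shown sit. So compound 2 stands at the limit, with no measured number to place it.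

Compound 3, `CCc1cccc(CC[C@H](O)CC[C@@H]2[C@@H](CCCCCCC(=O)O)[C@@H](O)C[C@H]2O)c1`, differs from compound 2 by 3-ethylphenyl in place of 4-methoxyphenyl on a saturated chain carbon, three bonds along the chain from an oxygen on a saturated carbon. Within the data shown here, the only measured step, from compound 1 to compound 2, was unreadable, so it gives no size to carry over. With both known compounds at the limit, the expectation for compound 3 in this assay is that it too will most likely sit at or beyond the limit, and the step that the limit leaves unreadable from compound 2 to compound 3 is estimated as none beyond the scatter that can be seen. Compound 3 is thus estimated at 15000 nM, within 3000 nM to 80000 nM.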

Compound 3, half-maximal inhibitory concentration: > 10000 nM
Compound 3 gave a limit, no number (the forecaster's own chance of this, stated with the estimate: 75%); the middle value lies beyond the limit too.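

Compound 3 also stands at a limit and not at a number, so neither step to it, from compound 1 or from compound 2, can be read: the limit of > 10000 nM in this assay, at which 3 of the 3 values shown sit.

The compounds shown leave open whether any aryl group on the shared core gives a measured number in this assay and how far past the limit these three compounds lie.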